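Swapping a sugar ring for an open diol

This account rests on a few compounds, and the source may have more. Where it says the series, first, only, none or still open, it means among the compounds named here.

Measured in a functional assay on SH-SY5Y cells (Homo sapiens) for cytotoxicity, read by MTT assay, with a stated time of 72 h; a higher number here means a weaker inhibitor, a lower number a stronger inhibitor
- Compound 1 `CN(C)CCCCCn1c2c(c3ccccc31)C(=O)c1c[n+]([O-])c3ccccc3c1C2=O` gives 370 nM
- Compound 2 `O=C1c2c[n+]([O-])c3ccccc3c2C(=O)c2c1c1ccccc1n2CCCCn1ccnc1` gives 130 nM
- Compound 3 `O=C1c2c[n+]([O-])c3ccccc3c2C(=O)c2c1c1ccccc1n2Cc1cn([C@@H]2C[C@H](O)[C@@H](CO)O2)nn1` gives 150 nM

Compound 3 stands at 150 nM in this assay and so lies within the scatter of compound 2, while compound 1 at 370 nM has a higher number, beyond the scatter.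

Compound 4 `O=C1c2c[n+]([O-])c3ccccc3c2C(=O)c2c1c1ccccc1n2Cc1cn(C[C@H](O)CO)nn1` differs from compound 3 in one place, where 2,3-dihydroxypropyl takes the place of 4-hydroxy-5-(hydroxymethyl)oxolan-2-yl on an aromatic nitrogen of a five-membered aromatic ring with 3 nitrogen. Within the data shown here, the count of that change is 2,3-dihydroxypropyl in place of 4-hydroxy-5-(hydroxymethyl)oxolan-2-yl on an aromatic nitrogen and no measured step exchanges these two groups.

Among the measured compounds shown here, the only measured step, a 2.8-fold lower number from compound 1 to compound 2 (0.45 log units; beyond the scatter) concerns a different group on a saturated chain, and it was modest. It therefore bears on this change only loosely. Compound 2 at 130 nM and compound 3 at 150 nM carry very different groups on the shared core, yet their values agree within the scatter, so a large step is not expected here. The expected step is a 1.2-fold higher number from compound 3 to compound 4 (0.08 log units; within the scatter) and that amounts to none beyond the scatter. Compound 4 is estimated at 180 nM with an expected range from 80 nM to 420 nM once it is measured.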

Compound 4, half-maximal inhibitory concentration: > 1000 nM
Compound 4 ended at the assay's limit; the forecaster's own chance of this, stated with the estimate: 2%; middle value at least 5.5-fold (0.74 log units) away from the limit.
By their numbers in this assay, from the lowest: compounds 2 and 3 (each within the scatter of the next); then compound 1. At a limit, above all of these: compound 4.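

In this assay compound 4 gives > 1000 nM, which is a limit of the assay and not a number: the limit of > 1000 nM in this assay, at which 1 of the 4 values shown sits.

The earlier compounds shown here gave no sign that this position was sensitive, yet 2,3-dihydroxypropyl in place of 4-hydroxy-5-(hydroxymethyl)oxolan-2-yl on an aromatic nitrogen of the five-membered aromatic ring with 3 nitrogen produces an at least 6.6-fold higher number from compound 3 to compound 4 (0.82 log units; beyond the scatter), although both groups have 2 hydrogen-bond donors and the entering group differs by having no ring, fewer heavy atoms and 1 defined stereocentre rather than 3. Compound 4 also separates from the compounds with quite different groups on the shared core, with an at least 7.6-fold higher number from compound 2 to compound 4 (0.88 log units; beyond the scatter) and an at least 2.7-fold higher number from compound 1 to compound 4 (0.43 log units; beyond the scatter), so among these four it is the weakest, with all three of its steps beyond the scatter.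

The compounds shown cannot tell whether the ring, its ring oxygen or its defined stereocentres account for the step, and how far compound 4 lies past its limit remains unknown. A cyclopentyl ring carrying two hydroxyl groups, or an unsubstituted oxolan-2-yl group, on that aromatic nitrogen would help to separate these features.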